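A few compounds are considered here, and "the series" means these few. Any claim that something is new, unique, unknown or untested is made for them only; others in the source may bear on it.

Measured so far:
compound 1 `Cc1ccccc1Nc1nc(Nc2ccc(N3CCN(C)CC3)cn2)ncc1Cl`: 8080 nM
compound 2 `Cc1ccccc1Nc1nc(Nc2ccc(N3CCNCC3)cn2)ncc1Cl`: 7870 nM
compound 3 `CCN1CCN(c2ccc(Nc3ncc(Cl)c(Nc4ccccc4C)n3)cc2)CC1`: 2060 nM

In a functional assay on Jurkat cells (Homo sapiens) for inhibition, read by CCK-8 assay, with a stated time of 48 h (on this read-out lower numbers stand for stronger inhibition of growth and higher numbers for weaker inhibition of growth), compound 1 sits at the upper end of the three numbers. Compound 2 cannot be told apart from it, since a 1.0-fold lower number from compound 1 to compound 2 (0.01 log units; within the scatter), while compound 3 gives a clearly lower number; compound 3 differs from compound 1 in more than one place, so only its value can be set beside that of compound 1.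

Compound 4 `CN1CCN(c2ccc(Nc3ncc(Cl)c(NCc4ccco4)n3)nc2)CC1` has not been measured. Its change from compound 1 is (furan-2-yl)methyl in place of 2-methylphenyl on a nitrogen on an aromatic ring. Among the measured compounds shown here, no measured step touches this part of the shared core; the single measured step, a 1.0-fold lower number from compound 1 to compound 2 (0.01 log units; within the scatter), concerns another position and stays within the scatter. No direction can therefore be drawn from the data, and the expectation for this assay is no step beyond the scatter, with a wide range. Compound 4 is estimated at 8000 nM, between 2500 nM and 25000 nM, which means an expected 1.0-fold lower number from compound 1 to compound 4 (0.00 log units; within the scatter).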

Compound 4, concentration for 50% growth inhibition: > 100000 nM
Compound 4: no number, only a limit; the forecaster's own chance of this, stated with the estimate: 15%; at least 12-fold (1.09 log units) between middle value and limit.
By their numbers in this assay, from the lowest: compound 3; then compounds 2 and 1 (each within the scatter of the next). At a limit, above all of these: compound 4.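

In this assay, placing (furan-2-yl)methyl instead of 2-methylphenyl on this nitrogen gives an at least 12-fold higher number from compound 1 to compound 4 (1.09 log units; beyond the scatter). The value for compound 4 is a limit of the assay, not a number: the limit of > 100000 nM in this assay, at which 1 of the 4 values shown sits.

This nitrogen's group can therefore shift growth inhibition strongly, whereas the amine nitrogen in a ring gave only a 1.0-fold lower number from compound 1 to compound 2 (0.01 log units; within the scatter). The swap alters both the ring and its attachment, and the compounds shown do not separate these two changes. From the compounds shown here alone, how a benzyl group on this nitrogen would behave remains open.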